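The source may report more compounds than this note shows. Statements on the series, on what has been measured and on what is new or still open speak of the compounds shown alone.

Compound 1 `Nc1ccccc1NC(=O)c1ccc(CNC(=O)c2cc3cccnc3[nH]2)cc1`: > 2000 nM in an assay on isolated protein for inhibition of Nicotinamide phosphoribosyltransferase (Homo sapiens), read by fluorescence, with stated times of 5 min and 15 min; on this read-out lower numbers stand for stronger inhibition and higher numbers for weaker inhibition.
Compound 2 `Nc1ccccc1NC(=O)c1ccc(NC(=S)NCc2ccccc2F)cc1`: > 2000 nM.
Compound 3 `Nc1ccccc1NC(=O)c1ccc(Cn2cc(-c3ccc(NC(=O)NCc4cccnc4)cc3)nn2)cc1`: 18 nM.

Compound 2 returns > 2000 nM in this assay, which is a limit of the assay and not a number. Compound 1 likewise sits at a limit, > 2000 nM. A number is returned only for compound 3, 18 nM. Compound 2 thus stands at the limit of > 2000 nM in this assay, at which 2 of the 3 values shown sit, and nothing more can be read from its entry than that.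

Compound 4 `Nc1ccccc1NC(=O)c1ccc(NC(=S)NCc2cccc(Cl)c2)cc1` differs from compound 2 by 3-chlorophenyl in place of 2-fluorophenyl on a saturated chain carbon bound to an amide-type nitrogen. Among the compounds with values here, no measured pair differs in one place, so no step size in this assay is known from the data. Since compound 2 is itself a limit, no movement beyond the scatter can be expected to show for the change to compound 4; the expectation is a further limit, or a number near it. Compound 4 is estimated at 4000 nM, with a range from 1000 nM to 20000 nM. The step this estimate means, a step that the limit leaves unreadable from compound 2 to compound 4, is expected to stay within the scatter.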

Compound 4, half-maximal inhibitory concentration: > 2000 nM
Compound 4: no number, only a limit (the forecaster's own chance of this, stated with the estimate: 75%); the middle value does not contradict the limit.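

Compound 2 and compound 4 both stand at a limit of the assay and not at a number, so no step can be read between them: the limit of > 2000 nM in this assay, at which 3 of the 4 values shown sit.

The compounds shown leave open whether 3-chlorophenyl in place of 2-fluorophenyl changes inhibition at all.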